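The source may report more compounds than this note shows. Statements on the series, on what has been measured and on what is new or still open speak of the compounds shown alone.

Compound 1 `CNC(=O)c1cc(Oc2ccc(NC(=O)c3nn(-c4ccccc4C(F)(F)F)c(=O)cc3C)cc2F)ccn1`: > 40000 nM in a functional assay on HepG2 cells (Homo sapiens) for cytotoxicity, read by MTT assay, with a stated time of 72 h (a lower number here means a stronger inhibitor, a higher number a weaker inhibitor), a limit
Compound 2 `CNC(=O)c1cc(Oc2ccc(NC(=O)c3nn(-c4ccc(Br)cc4F)c(=O)cc3C)cc2F)ccn1`: 2830 nM in this assay
Compound 3 `CNC(=O)c1cc(Oc2ccc(NC(=O)c3nn(-c4ccccc4F)c(=O)cc3C)cc2F)ccn1`: > 40000 nM in this assay, a limit

On these data alone, compound 1 gives only a limit in this assay, so its own number is unknown (the limit of > 40000 nM in this assay, at which 2 of the 3 values shown sit). Only compound 2 yields a number; the step of an at least 14-fold lower number from compound 1 to compound 2 (1.15 log units; beyond the scatter) shows how far below that limit it lies.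

Compound 4 `Cc1cc(=O)n(-c2ccccc2C(F)(F)F)nc1C(=O)Nc1ccc(Oc2ncnc3ccsc23)c(F)c1` differs from compound 1 at the other end of the shared core: a group of 9 heavy atoms (6 carbon, 2 nitrogen, 1 sulfur; one five-membered aromatic ring with 1 hetero atom, one six-membered aromatic ring with 2 hetero atoms) in place of a group of 10 heavy atoms (7 carbon, 2 nitrogen, 1 oxygen; one six-membered aromatic ring with 1 hetero atom), on an oxygen on an aromatic ring. The measured steps of an at least 14-fold lower number from compound 1 to compound 2 (1.15 log units; beyond the scatter) and an at least 14-fold higher number from compound 2 to compound 3 (1.15 log units; beyond the scatter) concern the group on the aromatic nitrogen, not this aryl ether, so none bears on the change. Because compound 1 stands at a limit (the limit of > 40000 nM in this assay, at which 2 of the 3 values shown sit), the step of an at least 2.0-fold lower number from compound 1 to compound 4 (0.30 log units; that floor lies within the scatter) is expected but cannot be anchored. Compound 4 is estimated at 20000 nM, within 3000 nM to 40000 nM.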

Compound 4, half-maximal inhibitory concentration: 9380 nM
Estimate against measurement, compound 4: 2.1-fold (0.33 log units) above, and the stated range covers the measured number.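

The earlier steps shown here concerned only the group on the aromatic nitrogen, whereas this one shows that the group on the oxygen on an aromatic ring also changes the result. In this assay the swap gives an at least 4.2-fold lower number from compound 1 to compound 4 (0.62 log units; beyond the scatter) while 2-(trifluoromethyl)phenyl stays in place. On these data alone, the true size of this step remains unknown, because compound 1 gives only a limit: the limit of > 40000 nM in this assay, at which 2 of the 4 values shown sit.

As far as these compounds go, whether the new group would act the same way alongside 4-bromo-2-fluorophenyl remains open. So does the effect of a carboxylic acid in place of the methylcarbamoyl group.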